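Amino for nitro on the methoxy-bearing ring

This account rests on a few compounds, and the source may have more. Where it says the series, first, only, none or still open, it means among the compounds named here.

Measured in a functional assay on K562 cells (Homo sapiens) for cytotoxicity, read by MTT assay, with a stated time of 48 h; on this read-out higher numbers stand for weaker inhibition and lower numbers for stronger inhibition
compound 1 `COc1cc(-n2c(-c3ccc(Br)cc3)cn(C(C)=O)c2=O)cc(OC)c1OC` gives 1000 nM
compound 2 `COc1ccc(-c2cn(C(C)=O)c(=O)n2-c2cc(OC)c(OC)c(OC)c2)cc1` gives 200 nM
compound 3 `COc1ccc(-c2cn(C(C)=O)c(=O)n2-c2cc(OC)c(OC)c(OC)c2)cc1[N+](=O)[O-]` gives > 50000 nM

Compound 3 gives only a limit, not a number (> 50000 nM). Going by the values given here, that reading is the limit of > 50000 nM in this assay, at which 1 of the 3 values shown sits, and is the only such reading so far.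

The next compound is compound 4 `COc1ccc(-c2cn(C(C)=O)c(=O)n2-c2cc(OC)c(OC)c(OC)c2)cc1N`, with amino in place of nitro on an aromatic carbon. Among the compounds with values here, two measured steps bear on this change. Nitro in place of hydrogen on an aromatic carbon gave a large rise (an at least 250-fold higher number from compound 2 to compound 3 (2.39 log units; beyond the scatter)), so the nitro group that now leaves marks the one large loss in the series. Methoxy in place of bromo on an aromatic carbon gave a modest fall (a 5.0-fold lower number from compound 1 to compound 2 (0.70 log units; beyond the scatter)). Within the data shown here, no amino compound has been measured, so the range stays wide.

A large fall is expected in this assay, back towards the level of compound 2. The estimated step is large (an at least 120-fold lower number from compound 3 to compound 4 (2.09 log units; beyond the scatter)). Compound 4 is expected at 400 nM (estimated range 40 nM to 5000 nM).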

Compound 4, half-maximal inhibitory concentration: 500 nM
Beside the measured number, compound 4's estimate is 1.3-fold (0.10 log units) below it; low and high end bracket the measured number.
By their numbers in this assay, from the lowest: compound 2; then compounds 4 and 1 (each within the scatter of the next). At a limit, above all of these: compound 3.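

Compound 3 stands at a limit of the assay and not at a number: the limit of > 50000 nM in this assay, at which 1 of the 4 values shown sits.
Read against that limit, an at least 100-fold lower number from compound 3 to compound 4 (2.00 log units; beyond the scatter) shows that in this assay a substituent on this carbon, ortho to a methoxy group, need not cost the activity, so the large loss follows the nitro group and not substitution at this place as such. Amino is still not the same as hydrogen here: a 2.5-fold higher number from compound 2 to compound 4 (0.40 log units; beyond the scatter) is a modest step, while a 2.0-fold lower number from compound 1 to compound 4 (0.30 log units; within the scatter) leaves the 3-amino-4-methoxyphenyl and 4-bromophenyl groups without a separation in this assay.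

Open, on these data alone, is how far this place accepts other groups: a hydroxyl, a dimethylamino group or an acetamide on the same carbon would show whether the recovery extends beyond amino. Also open, as far as these compounds go, is whether a nitro group brings the same loss on the ring that carries the bromo group in compound 1.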